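The source may report more compounds than this note shows. Statements on the series, on what has been measured and on what is new or still open speak of the compounds shown alone.

Working notes on the series, followed in a functional assay on PC-3 cells (Homo sapiens) for antiproliferative activity, with a stated time of 48 h; a lower number here means a stronger inhibitor, a higher number a weaker inhibitor. Compound 1 (`CCN(CC)c1ccc(-c2cccc(OC)c2)nn1`) gives > 25000 nM, which is a limit of the assay and not a number. Compound 2 (`CCN(CC)c1ccc(-c2ccc(C(=O)O)cc2)nn1`) gives > 25000 nM, which is also a limit. Going by the values given here, the series so far stands at the limit of > 25000 nM in this assay, at which 2 of the 2 values shown sit, so compound 1 cannot be placed above or below compound 2, and no measured step is available as a guide.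

The next compound is compound 3 (`CCOC(=O)c1cccc(-c2ccc(N(CC)CC)nn2)c1`). It carries ethoxycarbonyl in place of methoxy on an aromatic carbon, meta to a large group: ethoxycarbonyl in place of methoxy on an aromatic carbon.

The expectation rests on compound 1, whose reading of > 25000 nM is a limit with no number behind it. The expected size of a step that the limit leaves unreadable from compound 1 to compound 3 is nothing beyond the usual scatter, in no clear direction. Another reading that is only a limit is the more likely outcome in this assay. The estimate for compound 3 is 28000 nM, expected to fall within 12000 nM to 60000 nM.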

Compound 3, half-maximal inhibitory concentration: > 25000 nM
Compound 3: no number, only a limit; the forecaster's own chance of this, stated with the estimate: 75%; the middle value is on the limit's open side.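

In this assay compound 3 gives > 25000 nM, which is a limit of the assay and not a number, so the step from compound 1 to compound 3 cannot be read. All readings in the series now coincide: the limit of > 25000 nM in this assay, at which 3 of the 3 values shown sit.

The compounds shown leave open how compound 1, compound 2 and compound 3 rank against one another.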